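Isopropyl for methyl on compound 1: expected step

This account rests on a few compounds, and the source may have more. Where it says the series, first, only, none or still open, it means among the compounds named here.

In a functional assay on the whole organism with Scenedesmus acutus as the target (a higher number here means a weaker inhibitor, a lower number a stronger inhibitor), compound 1 `COC(=O)c1cc(N2C(=O)C3=C(CCCC3)C2=O)ccc1Cl` gives 2000 nM as the highest of the three numbers in hand, which makes it the weakest inhibitor of the set. Compound 2 `COC(=O)c1cc(N2C(=O)C3=C(CCCC3)C2=O)c(F)cc1Cl` reads 110 nM and compound 3 `CCCOC(=O)c1cc(N2C(=O)C3=C(CCCC3)C2=O)c(F)cc1Cl` reads 89.1 nM on the same scale.

Compound 4 `CC(C)OC(=O)c1cc(N2C(=O)C3=C(CCCC3)C2=O)ccc1Cl` differs from compound 1 by a single change isopropyl in place of methyl on an oxygen next to a carbonyl group that puts isopropyl in place of methyl on an oxygen next to a carbonyl group. Two measured steps are available. The step of an 18-fold lower number from compound 1 to compound 2 (1.26 log units; beyond the scatter) is large, but it is fluoro in place of hydrogen on an aromatic carbon, a change compound 4 does not carry, so it gives no direct guide here. The step of a 1.2-fold lower number from compound 2 to compound 3 (0.09 log units; within the scatter) bears more closely, since it also alters the group on that oxygen, and it stays within the scatter. That step was measured with the fluoro present, and isopropyl itself has not been measured in any compound, so the transfer is uncertain. No step beyond the scatter is therefore expected in this assay for this change. An expected step of a 1.3-fold lower number from compound 1 to compound 4 (0.10 log units; within the scatter) is the working estimate. The expected value for compound 4 is 1600 nM with a range of 700 nM to 3500 nM as estimated here.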

Compound 4, half-maximal inhibitory concentration: 1000 nM
Estimate against measurement, compound 4: 1.6-fold (0.20 log units) above; the range from low to high includes it.
By their numbers in this assay, from the lowest: compounds 3 and 2 (each within the scatter of the next); then compounds 4 and 1 (each within the scatter of the next).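

In this assay, the group on the oxygen next to a carbonyl group now has a reading on the compound without the fluoro, where isopropyl in place of methyl gives a 2.0-fold lower number from compound 1 to compound 4 (0.30 log units; within the scatter). Set beside a 1.2-fold lower number from compound 2 to compound 3 (0.09 log units; within the scatter), this gives two changes at this place, one with the fluoro present and one without it, and neither goes beyond the scatter, so in these four compounds methyl, propyl and isopropyl on this oxygen do not separate, while the fluoro change, at an 18-fold lower number from compound 1 to compound 2 (1.26 log units; beyond the scatter), remains the only step beyond the scatter. Nothing measured here bears on the reason for this result.

Still open, from the compounds shown here alone, is whether the fluoro step keeps its size on the isopropyl compound, which would show whether the two places act independently in compound 4 as they appear to in the methyl pair. Also open, going by these compounds, is how far this tolerance extends, for instance to a longer chain on this oxygen, or to a carboxylic acid or an amide in place of the ester.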